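Swapping a methoxyphenyl group for a trifluorophenyl group

The compounds below may be only part of what the source reports. "The series", "measured", "known", "first", "only" and "open" are said of these compounds alone.

In a functional assay on MCF cells (Homo sapiens) for antiproliferative activity, with a stated time of 72 h (on this read-out higher numbers stand for weaker inhibition and lower numbers for stronger inhibition), compound 1 `OC[C@H]1O[C@@H](n2cnc3c(NCc4ccc(F)cc4)ncnc32)[C@H](O)[C@@H]1O` gives 21000 nM. Compound 2 `COc1ccccc1CNc1ncnc2c1ncn2[C@@H]1O[C@H](CO)[C@@H](O)[C@H]1O` yields only a limit, > 166000 nM. Compound 3 `COc1cccc(CNc2ncnc3c2ncn3[C@@H]2O[C@H](CO)[C@@H](O)[C@H]2O)c1` also yields only a limit, > 166000 nM. Compound 3 therefore has no exact number and shares (the limit of > 166000 nM in this assay, at which 2 of the 3 values shown sit).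

Compound 4 `OC[C@H]1O[C@@H](n2cnc3c(NCc4c(F)ccc(F)c4F)ncnc32)[C@H](O)[C@@H]1O` carries 2,3,6-trifluorophenyl in place of 3-methoxyphenyl, on a saturated chain carbon bound to a nitrogen on an aromatic ring: 2,3,6-trifluorophenyl in place of 3-methoxyphenyl on a saturated chain carbon bound to a nitrogen on an aromatic ring.

The most relevant evidence runs the opposite way, from a fluorinated group to a methoxy one. There is an at least 7.9-fold higher number from compound 1 to compound 3 (0.89 log units; beyond the scatter), and likewise an at least 7.9-fold higher number from compound 1 to compound 2 (0.89 log units; beyond the scatter). The two methoxy compounds cannot be ranked, with a step that the two limits leave unreadable from compound 2 to compound 3.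

Going by the values given here, compound 1, at 21000 nM, is the only measured compound with fluorine, and its 4-fluorophenyl group is not the group in compound 4. A lower number of modest size is therefore expected, with real uncertainty. The expected change is an at least 3.6-fold lower number from compound 3 to compound 4 (0.56 log units; beyond the scatter). For compound 4, the estimate is 45000 nM, with an expected range from 12000 nM to 150000 nM.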

Compound 4, half-maximal inhibitory concentration: > 166000 nM
Compound 4 gave a limit, no number (the forecaster's own chance of this, stated with the estimate: 25%); at least 3.6-fold (0.56 log units) between middle value and limit.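

Fluorine on the phenyl ring does not by itself give a readable value in this assay, and compound 4 joins the two methoxy compounds at a limit rather than a number: the limit of > 166000 nM in this assay, at which 3 of the 4 values shown sit. The change from 4-fluorophenyl to 2,3,6-trifluorophenyl gives an at least 7.9-fold higher number from compound 1 to compound 4 (0.89 log units; beyond the scatter), so among these compounds the fluorine pattern on the ring matters, not merely the presence of fluorine. The steps from compound 2 and from compound 3 to compound 4 cannot be read, as both ends of each are limits.

On these data alone, it remains open whether a plain phenyl group or a 4-chlorophenyl group at this place would give a number, and so whether the fluorine of compound 1 matters at all. Compound 2, compound 3 and compound 4 also cannot be ranked against one another.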